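Ureido in place of hydroxy: the step from compound 1

A few compounds are considered here, and "the series" means these few. Any claim that something is new, unique, unknown or untested is made for them only; others in the source may bear on it.

For the measured compounds named here, in a functional assay on SK-OV-3 cells (Homo sapiens) for cytotoxicity, read by MTT assay, with a stated time of 3 days (a lower number here means a stronger inhibitor, a higher number a weaker inhibitor), compound 1 `N#Cc1c(O)nc(SCc2nc3ccccc3[nH]2)nc1-c1ccccc1` gives 2.55 nM, the lowest of the two numbers measured so far. Going by the values given here, compound 2 `CCNc1nc(SCc2nc3ccccc3[nH]2)nc(-c2ccccc2)c1C#N` gives 7.35 nM; the step of a 2.9-fold higher number from compound 1 to compound 2 (0.46 log units; beyond the scatter) is the only measured change on that aromatic carbon. Compound 3 `N#Cc1c(NC(N)=O)nc(SCc2nc3ccccc3[nH]2)nc1-c1ccccc1` differs from compound 1 by ureido in place of hydroxy on an aromatic carbon. The same hydroxy leaves, so a comparable modest weakening is expected, although ureido is a different group and nothing measured speaks to it directly. The step is expected to be a 2.4-fold higher number from compound 1 to compound 3 (0.37 log units; beyond the scatter). For compound 3 the estimate is 6 nM, with a range from 2 nM to 18 nM.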

Compound 3, half-maximal inhibitory concentration: 6.75 nM
Compound 3: middle estimate off by 1.1-fold (0.05 log units), on the low side; the range from low to high includes it.
By their numbers in this assay, from the lowest: compound 1; then compounds 3 and 2 (each within the scatter of the next).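

With ureido on this aromatic carbon, the change from hydroxy gives a 2.6-fold higher number from compound 1 to compound 3 (0.42 log units; beyond the scatter) and so shows that the rise in the number is not confined to ethylamino. Carbamoyl in place of ethyl on the nitrogen gives a 1.1-fold lower number from compound 2 to compound 3 (0.04 log units; within the scatter) and so leaves these two nitrogen-bearing groups unseparated. No evidence on hand bears on either step. On these data alone, whether a free amine or a methoxy group on this carbon would sit with compound 1 or with compounds 2 and 3 remains open.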